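A few compounds are considered here, and "the series" means these few. Any claim that something is new, unique, unknown or untested is made for them only; others in the source may bear on it.

Compound 2, with the structure `CC(C)(O)CNc1cc(Oc2ccc(NC(=O)Nc3cccc(C(F)(F)F)c3)cc2)ncn1`, gives 40 nM in an assay on isolated protein for inhibition of serine/threonine-protein kinase TNNI3K (Homo sapiens); on this read-out lower numbers stand for stronger inhibition and higher numbers for weaker inhibition. Of the two numbers shown it is the one standing highest on paper, but its only neighbour, compound 1 with the structure `Nc1cc(Oc2ccc(NC(=O)Nc3cccc(C(F)(F)F)c3)cc2)ncn1`, gives 25 nM, and the step of a 1.6-fold higher number from compound 1 to compound 2 (0.20 log units; within the scatter) lies within the scatter, so the two compounds cannot be told apart on this read-out. Compound 3, with the structure `C[C@H](O)CNc1cc(Oc2ccc(NC(=O)Nc3cccc(C(F)(F)F)c3)cc2)ncn1`, differs from compound 2 in one place: 1-hydroxyethyl in place of 1-hydroxy-1-methylethyl on a saturated chain carbon bound to a nitrogen on an aromatic ring. For the measured compounds named here, the single measured step that bears on this region is a 1.6-fold higher number from compound 1 to compound 2 (0.20 log units; within the scatter), which shows that attaching the whole 2-hydroxy-2-methylpropyl chain to the ring nitrogen left the number within the scatter. Trimming one methyl from that chain is a smaller change than adding the chain, so the author expects no step beyond the scatter, a 1.1-fold lower number from compound 2 to compound 3 (0.06 log units; within the scatter). Compound 3 is estimated at 35 nM, with a range of 18 nM to 70 nM.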

Compound 3, half-maximal inhibitory concentration: 32 nM
Beside the measured number, compound 3's estimate is 1.1-fold (0.04 log units) above it, and the stated range covers the measured number.
By their numbers in this assay, from the lowest: compounds 1, 3 and 2 (each within the scatter of the next).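

In this assay the change from 2-hydroxy-2-methylpropyl to 2-hydroxypropyl gives a 1.3-fold lower number from compound 2 to compound 3 (0.10 log units; within the scatter), so at this position the two chains cannot be told apart. Set against hydrogen on the same nitrogen, 2-hydroxypropyl gives a 1.3-fold higher number from compound 1 to compound 3 (0.11 log units; within the scatter), which means that a second, differently branched hydroxyalkyl chain also stays within the scatter of compound 1, and all three compounds now read alike on this measure. No independent measurement is available that would explain this flat picture.

The compounds shown leave open whether the opposite configuration at the defined stereocentre of compound 3 would read the same. They also leave open whether an amine, a carboxylic acid or a longer chain on this nitrogen would produce a step beyond the scatter.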